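Aryl urea swap on compound 2: bromo to fluoro

This account rests on a few compounds, and the source may have more. Where it says the series, first, only, none or still open, it means among the compounds named here.

Measured so far in a functional assay on L1210 cells (Mus musculus) for inhibition, read by MTT assay, with a stated time of 72 h; on this read-out lower numbers stand for stronger inhibition and higher numbers for weaker inhibition:
compound 1 `COc1cc(NC(C)CCCNC(=O)Nc2cccc(Cl)c2)c2ncccc2c1` gives 17000 nM
compound 2 `COc1cc(NC(C)CCCNC(=O)Nc2ccc(Br)cc2)c2ncccc2c1` gives 18000 nM
compound 3 `COc1cc(NC(C)CCCNC(=O)NNC(=O)Nc2ccc(C(F)(F)F)cc2)c2ncccc2c1` gives 18000 nM

Compound 2 stands level with compound 3 at the digits shown, the two together the highest numbers of the three; compound 1 sits a hair lower, and the step of a 1.1-fold higher number from compound 1 to compound 2 (0.02 log units; within the scatter) lies within the scatter. Compound 4 `COc1cc(NC(C)CCCNC(=O)Nc2ccc(F)cc2)c2ncccc2c1` has not yet been run in this assay. Its change from compound 2 is fluoro in place of bromo on an aromatic carbon. Going by the values given here, the one measured step that touches the same six-membered ring is a 1.1-fold higher number from compound 1 to compound 2 (0.02 log units; within the scatter), 4-bromophenyl in place of 3-chlorophenyl, which moved the number by nothing beyond the scatter; compound 3, built differently at the urea, also lands on the same figure. Nothing measured in this assay has moved the read-out beyond the scatter, so fluoro in place of bromo is expected to give no step beyond the scatter either. For compound 4 the expected step is no change at the digits printed from compound 2 to compound 4 (within the scatter). Compound 4 is therefore estimated at 18000 nM in this assay, with a range of 9000 nM to 36000 nM.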

Compound 4, half-maximal inhibitory concentration: 18000 nM
The estimate for compound 4 equals the measured number at the digits printed; the measured number falls inside the stated range.
By their numbers in this assay, from the lowest: compounds 1, 2, 3 and 4 (each within the scatter of the next).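

In this assay, exchanging the halogen on the aromatic carbon para to a large group gives no change at the digits printed from compound 2 to compound 4 (within the scatter), so at this site bromo and fluoro cannot be told apart on this read-out. The step of a 1.1-fold higher number from compound 1 to compound 4 (0.02 log units; within the scatter) also stays inside the scatter, which places 4-fluorophenyl with 4-bromophenyl and 3-chlorophenyl as aryl groups on the urea that show no difference from one another here. No supporting data bear on why the read-out stays flat across these halogen changes.

On these data alone, it remains open whether a group of another kind on this aromatic carbon, such as an amine, a carboxylic acid or a nitrile, would give a step beyond the scatter. Also open, as far as these compounds go, is whether a longer chain between the shared core and the urea would move the number at all.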